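This account rests on a few compounds, and the source may have more. Where it says the series, first, only, none or still open, it means among the compounds named here.

In a functional assay on MCF7 cells (Homo sapiens) for antiproliferative activity, read by MTT assay, with a stated time of 72 h (a lower number here means a stronger inhibitor, a higher number a weaker inhibitor), compound 1 `O=C(Nc1cccc(C(=O)O/N=C2\CCCc3noc(-c4cccc(F)c4)c32)c1)c1cccc(F)c1` gives only a limit, > 25000 nM, and no number. Compound 2 `CC1(C)C/C(=N\OC(=O)c2cccc(NC(=O)c3cccc(F)c3)c2)c2c(noc2-c2cccc(F)c2)C1` likewise gives only a limit in this assay, > 25000 nM. Both measured values sit at the limit of > 25000 nM in this assay, at which 2 of the 2 values shown sit, so compound 2 stands with no measurable strength against the cells within the range that this assay reports. Compound 3 `COc1ccc(-c2onc3c2/C(=N/OC(=O)c2cccc(NC(=O)c4cccc(F)c4)c2)CC(C)(C)C3)cc1OC` differs from compound 2 in one place: 3,4-dimethoxyphenyl in place of 3-fluorophenyl on an aromatic carbon. Among the measured compounds shown here, no measured step connects any pair of compounds here, so the effect of this exchange is unknown from the data, and the expectation is that a step that the limit leaves unreadable from compound 2 to compound 3 brings no change beyond the scatter. Compound 3 is accordingly estimated at 30000 nM in this assay, with a range from 8000 nM to 120000 nM, and most likely again only a limit.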

Compound 3, half-maximal inhibitory concentration: > 25000 nM
Compound 3 was reported as a limit; the forecaster's own chance of this, stated with the estimate: 80%; the middle value is on the limit's open side.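

Compound 2 and compound 3 each give only a limit in this assay, not a number, so no step between them can be read: the limit of > 25000 nM in this assay, at which 3 of the 3 values shown sit.

The compounds shown leave open whether 3,4-dimethoxyphenyl in place of 3-fluorophenyl changes strength against these cells at all.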